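Working notes: from compound 3 to compound 4

A few compounds are considered here, and "the series" means these few. Any claim that something is new, unique, unknown or untested is made for them only; others in the source may bear on it.

Measured so far:
compound 1 `O=C(Nc1cccc(-n2cc(-c3ccncc3)c(-c3cc(O)cc(Cl)c3)n2)c1)Nc1ccc(Cl)c(Cl)c1`: 53%
compound 2 `COc1cc(Cl)cc(-c2nn(-c3cccc(NC(=O)Nc4cc(C(F)(F)F)cc(C(F)(F)F)c4)c3)cc2-c2ccncc2)c1`: 99%
compound 3 `COc1cc(Cl)cc(-c2nn(-c3cccc(NC(=O)Nc4ccc(Cl)c(Cl)c4)c3)cc2-c2ccncc2)c1`: 93%

In a functional assay on OVCAR-5 cells (Homo sapiens) for inhibition, read by sulforhodamine B assay, with a stated time of 48 h, tested at 0.01 uM (a lower number here means a stronger effect, a higher number a weaker effect of the compound at the concentration tested), compound 3 gives 93%, the second highest of the three numbers; compound 2 gives 99%, within the scatter of it, while compound 1 gives 53%, far below. Going by the values given here, the only single-point step measured is a number 40 percentage points higher from compound 1 to compound 3 (beyond the scatter), which concerns the oxygen on the aromatic ring, not the carbonyl carbon. Compound 4 `COc1cc(Cl)cc(-c2nn(-c3cccc(NC(=O)c4cccc(C(F)(F)F)c4)c3)cc2-c2ccncc2)c1` differs from compound 3 at the carbonyl carbon: 3-(trifluoromethyl)phenyl in place of (3,4-dichlorophenyl)amino on a carbonyl carbon. Among the compounds with values here, no measured step touches this place, so there is no direct guide; of compound 2 and compound 3 one can say only that both read high. The step of a number 3 percentage points lower from compound 3 to compound 4 (within the scatter) is therefore expected to lie within the scatter. For compound 4 the estimate is 90%, with a range from 70% to 105%.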

Compound 4, a percentage reported as activity, at one concentration (the size of the read-out at that concentration, not a potency): 58%
Beside the measured number, compound 4's estimate is 32 percentage points above it, outside the stated range (below it).
By their numbers in this assay, from the lowest: compounds 1 and 4 (each within the scatter of the next); then compounds 3 and 2 (each within the scatter of the next).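

In this assay, going by these compounds alone, the group on the carbonyl carbon proves to be a sensitive place: a number 35 percentage points lower from compound 3 to compound 4 (beyond the scatter), and the only earlier step concerned the oxygen on the aromatic ring. The change replaces the amino nitrogen with its hydrogen-bond donor and alters the ring substituents at once, so the two contributions cannot be separated here. Nothing available explains the step. Open, going by these compounds, is whether the nitrogen or the ring substituents carry the difference, which 3-(trifluoromethyl)phenylamino on the carbonyl carbon would test. Also open, on these data alone, is how a non-aromatic group such as morpholine would read at this place.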